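Swapping the Pendant Ring: From Compound 1 to Compound 3

The source may report more compounds than this note shows. Statements on the series, on what has been measured and on what is new or still open speak of the compounds shown alone.

Of the compounds shown here, two have been measured in an assay on CHO cells for displacement of a labelled ligand from Alpha-2C adrenergic receptor (Homo sapiens); a higher number here means a weaker inhibitor, a lower number a stronger inhibitor. Compound 1 `CC(Oc1ccccc1-c1ccc(O)cc1)C1=NCCN1` gives 331 nM, and compound 2 `CC(Oc1ccccc1-c1ccc([N+](=O)[O-])cc1)C1=NCCN1` gives 302 nM. Of these two numbers compound 1 stands highest, with compound 2 nearest, though the step of a 1.1-fold lower number from compound 1 to compound 2 (0.04 log units; within the scatter) lies within the scatter. Compound 3 `CC(Oc1ccccc1-c1ccccn1)C1=NCCN1` has not yet been measured. It differs from compound 1 in one place: pyridin-2-yl in place of 4-hydroxyphenyl on an aromatic carbon. Among the compounds with values here, no measured step covers this change directly. Within the data shown here, the only measured step bears on it loosely, as it exchanges one group for another on the very ring that is now replaced altogether, and that step left the number essentially unchanged. A modest step is therefore expected for compound 3, with no firm reason for either direction. Compound 3 is estimated at 400 nM, within a range of 120 nM to 1300 nM, which means an expected step of a 1.2-fold higher number from compound 1 to compound 3 (0.08 log units; within the scatter).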

Compound 3, inhibition constant: 1260 nM
Compound 3: the middle estimate sits 3.2-fold (0.50 log units) below what was measured; low and high end bracket the measured number.
By their numbers in this assay, from the lowest: compounds 2 and 1 (each within the scatter of the next); then compound 3.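

In this assay, pyridin-2-yl in place of 4-hydroxyphenyl brings a 3.8-fold higher number from compound 1 to compound 3 (0.58 log units; beyond the scatter) and is the only step shown that lies beyond the scatter. The exchange of hydroxy for nitro on the pendant ring moved the number by no more than the scatter, whereas replacing that ring as a whole shows that this aromatic carbon is not indifferent to what it carries. No available evidence bears on why the number rises with this change.

The compounds shown leave open whether this step belongs to the ring nitrogen of pyridin-2-yl or to the loss of the hydroxy group, and an unsubstituted phenyl ring would separate the two. They also leave open how an amine or a carboxylic acid on the pendant ring would compare.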